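The source may hold more compounds than are shown below. What is called first, only, known or untested is meant among the compounds shown, and "the series" means these compounds.

Measured in an ADME assay on Raji cells (Homo sapiens) for cytotoxicity, read by CellTiter-Glo and resazurin assay, with a stated time of 72 h; on this read-out lower numbers stand for an effect already at smaller amounts and higher numbers for an effect only at larger amounts of compound:
- compound 1 `CC(C)N(Cc1cccc(OCCCCCC(=O)O)c1)C(=O)c1ccc(-c2cccc3ccccc23)cc1` gives > 26000 nM, a limit of the assay
- compound 2 `CC(C)N(Cc1cccc(OCCCCCC(=O)O)c1)C(=O)c1ccc(-c2c[nH]c3ccccc23)cc1` gives > 26000 nM, a limit of the assay
- compound 3 `CCOC(=O)CCCCCOc1cccc(CN(C(=O)c2ccc(-c3cccc4ccccc34)cc2)C(C)C)c1` gives > 26000 nM, a limit of the assay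

Compound 3 therefore stands at the limit only, with no number of its own in this assay. Compound 4 `CCOC(=O)CCCCCOc1cccc(CN(C(=O)c2ccc(-c3ccoc3)cc2)C(C)C)c1` is its unmeasured partner, differing by furan-3-yl in place of naphthalen-1-yl on an aromatic carbon. The only measured steps, a step that the two limits leave unreadable from compound 1 to compound 2 and a step that the two limits leave unreadable from compound 1 to compound 3, stay unreadable because of the limit of > 26000 nM in this assay, at which 3 of the 3 values shown sit, so nothing shown gives a size for a swap at this position. Compound 4 is expected to remain at the limit as well, estimated at 30000 nM with a range of 15000 nM to 60000 nM. The expected step is a step that the limit leaves unreadable from compound 3 to compound 4, meaning no readable change is expected.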

Compound 4, half-maximal effective concentration: > 26000 nM
Compound 4 gave a limit, no number; the forecaster's own chance of this, stated with the estimate: 80%; the middle value does not contradict the limit.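

No step can be read between compound 3 and compound 4, since both give only a limit: the limit of > 26000 nM in this assay, at which 4 of the 4 values shown sit.

The compounds shown leave open at what concentration any of them would show an effect, and whether swapping the group on this aromatic carbon changes it.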